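The source may hold more compounds than are shown below. What is called first, only, known or untested is meant among the compounds shown, and "the series" means these compounds.

Compound 1 `C=CCc1cc(-c2ccc(F)cc2)ccc1O`: > 100000 nM
Compound 2 `C=CCc1cc(-c2ccc(C(F)(F)F)cc2)ccc1OC`: 78800 nM

Among the compounds with values here, in a functional assay on Lewis lung carcinoma cells (Mus musculus) for antiproliferative activity, read by MTT assay, with a stated time of 24 h (a lower number here means a stronger inhibitor, a higher number a weaker inhibitor), compound 2 gives 78800 nM, the only true number so far. Compound 1 gives > 100000 nM, which is a limit of the assay and not a number. Compound 3 `C=CCc1cc(-c2ccc(C(F)(F)F)cc2)ccc1O` changes compound 2 in one place: hydrogen in place of methyl on an oxygen on an aromatic ring, methoxy to hydroxy. Within the data shown here, no measured pair isolates this change, so the expectation rests on little. Compound 1, which also carries a hydroxy, stands at the limit of > 100000 nM. In this assay, the expected change is a 1.1-fold higher number from compound 2 to compound 3 (0.06 log units; within the scatter), a small weakening that stays within the usual scatter. Compound 3 is estimated at 90000 nM, with an expected range of 30000 nM to 200000 nM.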

Compound 3, half-maximal inhibitory concentration: 74800 nM
Compound 3: the middle estimate sits 1.2-fold (0.08 log units) above what was measured, and the stated range covers the measured number.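

Methoxy to hydroxy on an oxygen on an aromatic ring gives a 1.1-fold lower number from compound 2 to compound 3 (0.02 log units; within the scatter) in this assay, so at this position the methyl can go without a change that can be told from scatter. Trifluoromethyl in place of fluoro gives an at least 1.3-fold lower number from compound 1 to compound 3 (0.12 log units; that floor lies within the scatter), but that is only a floor, and it lies within the scatter. Compound 1 sits at a limit of the assay, not at a number: the limit of > 100000 nM in this assay, at which 1 of the 3 values shown sits.

Still open, as far as these compounds go, is whether a longer chain on this oxygen, or an amine or a carboxylic acid in place of trifluoromethyl, would move the number beyond the scatter.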